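This account rests on a few compounds, and the source may have more. Where it says the series, first, only, none or still open, it means among the compounds named here.

For the measured compounds named here, in an assay on CHO-K1 cells for displacement of a labelled ligand from adenosine receptor A1 (Homo sapiens), read by scintillation counting, with a stated time of 60 min (on this read-out lower numbers stand for stronger inhibition and higher numbers for weaker inhibition), compound 3 `CCCCC/C=C/C=C/C=N/Nc1nc(N)c2ncn([C@@H]3O[C@H](CO)[C@@H](O)[C@H]3O)c2n1` gives 2 nM, the lowest of the two numbers measured so far. Compound 1 `N#Cc1ccc(/C=N/Nc2nc(N)c3ncn([C@@H]4O[C@H](CO)[C@@H](O)[C@H]4O)c3n2)cc1` gives 4.1 nM, and a 2.1-fold lower number from compound 1 to compound 3 (0.31 log units; beyond the scatter). Compound 2 `Nc1nc(N/N=C/c2ccc(Cl)c(C(F)(F)F)c2)nc2c1ncn2[C@@H]1O[C@H](CO)[C@@H](O)[C@H]1O` gives > 10000 nM, which is a limit of the assay and not a number. Compound 4 `CC(=O)Nc1ccc(/C=N/Nc2nc(N)c3ncn([C@@H]4O[C@H](CO)[C@@H](O)[C@H]4O)c3n2)cc1` differs from compound 3 in one place: a group of 10 heavy atoms (8 carbon, 1 nitrogen, 1 oxygen; one six-membered aromatic ring of carbon only) in place of a group of 9 heavy atoms (9 carbon; no ring), on a carbon with a double bond to nitrogen. Going by the values given here, two measured steps bear on this change. The swap of an aromatic ring for the chain gave a modest gain, while the swap of one ring for another gave a large loss, as an at least 2400-fold higher number from compound 1 to compound 2 (3.38 log units; beyond the scatter) shows. Putting a ring back on compound 3 is therefore expected to give a modest rise, a 3.0-fold higher number from compound 3 to compound 4 (0.48 log units; beyond the scatter). Compound 4 is expected to give about 6 nM, between 2 nM and 30 nM.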

Compound 4, inhibition constant: > 10000 nM
Compound 4 gave a limit, no number; the forecaster's own chance of this, stated with the estimate: 5%; at least 1600-fold (3.22 log units) between middle value and limit.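

The value of compound 4 is a limit of the assay and not a number, and it is not alone there: the limit of > 10000 nM in this assay, at which 2 of the 4 values shown sit. At this carbon with a double bond to nitrogen, an aromatic ring does not by itself keep the number low: 4-acetamidophenyl in place of the chain gives an at least 5000-fold higher number from compound 3 to compound 4 (3.69 log units; beyond the scatter), and acetamido in place of cyano on the ring gives an at least 2400-fold higher number from compound 1 to compound 4 (3.38 log units; beyond the scatter). The step from compound 2 to compound 4 cannot be read, as both values are limits. As far as these compounds go, whether an amine or a carboxylic acid in place of acetamido would track cyano or acetamido stays open.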